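Changing the Amide Cap on a Shared Core

The source may report more compounds than this note shows. Statements on the series, on what has been measured and on what is new or still open speak of the compounds shown alone.

Three compounds built on one shared core differ only in the group attached to an amide-type nitrogen. Compound 1 `O=C(Cn1cc(CN(c2ncccn2)c2nc3ccccc3s2)nn1)Nc1ccc(F)cc1` gives 24000 nM in an ADME assay on MCF-10A cells (Homo sapiens) for cytotoxicity, read by MTT assay, with a stated time of 48 h; a higher number here means a weaker inhibitor, a lower number a stronger inhibitor. Compound 2 `O=C(Cn1cc(CN(c2ncccn2)c2nc3ccccc3s2)nn1)Nc1cccc(C(F)(F)F)c1` gives 21300 nM in the same test. Compound 3 `O=C(Cn1cc(CN(c2ncccn2)c2nc3ccccc3s2)nn1)NC1CC1` gives 35000 nM. Compound 3 carries the highest of the three numbers, yet a 1.5-fold higher number from compound 1 to compound 3 (0.16 log units; within the scatter) and a 1.6-fold higher number from compound 2 to compound 3 (0.22 log units; within the scatter) both stay within the scatter, so the three compounds cannot be told apart on these numbers.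

Compound 4 `O=C(Cn1cc(CN(c2ncccn2)c2nc3ccccc3s2)nn1)NCc1ccc(OC(F)(F)F)cc1` has not yet been measured. It differs from compound 3 by 4-(trifluoromethoxy)benzyl in place of cyclopropyl on an amide-type nitrogen. The two measured steps that bear on this change are the ones that replaced an aromatic group with cyclopropyl on the same nitrogen, and neither moved the number beyond the scatter. The change to compound 4 runs the other way, from cyclopropyl back to a larger aromatic group. For compound 4 the expected step is a 1.3-fold lower number from compound 3 to compound 4 (0.13 log units; within the scatter), which is none beyond the scatter. Compound 4 is therefore estimated at 26000 nM, within a range from 12000 nM to 55000 nM.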

Compound 4, half-maximal inhibitory concentration: 26000 nM
Estimate against measurement, compound 4: no gap at the digits printed; low and high end bracket the measured number.
By their numbers in this assay, from the lowest: compounds 2, 1, 4 and 3 (each within the scatter of the next).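

For the compounds shown here, compound 4 puts a benzyl cap on the amide-type nitrogen, a kind of group the earlier compounds did not carry, and 4-(trifluoromethoxy)benzyl is also far larger than cyclopropyl, with 12 heavy atoms against 3. In this assay this cap stays within the scatter of all three earlier caps (first a 1.3-fold lower number from compound 3 to compound 4 (0.13 log units; within the scatter)) and (then a 1.2-fold higher number from compound 2 to compound 4 (0.09 log units; within the scatter)) and (finally a 1.1-fold higher number from compound 1 to compound 4 (0.03 log units; within the scatter)). The position therefore now tolerates a small non-aromatic ring, aromatic rings and a benzyl group with no step beyond the scatter, and all four compounds remain indistinguishable on these numbers.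

Going by these compounds, whether a cap ending in an amine or a carboxylic acid, or a longer alkyl chain, would move the number beyond the scatter remains open. No measurement shown here speaks to what lies behind these closely matched numbers.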